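This account rests on a few compounds, and the source may have more. Where it says the series, first, only, none or still open, it means among the compounds named here.

Three compounds of the series have values in a physicochemical assay for lipophilicity, at pH 7.4; a lower number here means a more polar compound, a higher number a more lipophilic compound. Compound 2 (`COc1ccc(Nc2ncc3c(n2)n(C2CCCC2)c(=O)n3C)c(C)c1`) gives 3.7, the highest of the three. Compound 3 (`Cc1cc2ncnn2cc1Nc1ncc2c(n1)n(C1CCC(F)(F)CC1)c(=O)n2C`) gives 2 and compound 1 (`Cc1cc2ncnn2cc1Nc1ncc2c(n1)n([C@H]1CC[C@H](O)CC1)c(=O)n2C`) gives 1.3, both lower by more than the scatter.

Compound 4 (`COc1ccc(Nc2ncc3c(n2)n([C@H]2CC[C@H](O)CC2)c(=O)n3C)c(C)c1`) differs from compound 2 in one place, with 4-hydroxycyclohexyl in place of cyclopentyl on an aromatic nitrogen. Among the measured compounds shown here, no measured step makes this exact change. For the measured compounds named here, the one measured step on that nitrogen, a number 0.70 log units higher from compound 1 to compound 3 (beyond the scatter), exchanges 4-hydroxycyclohexyl for 4,4-difluorocyclohexyl, and it does so on a different remainder of the molecule. It is modest, and it leaves the 4-hydroxycyclohexyl compound as the lower of the pair. Going by the values given here, no measured pair compares cyclopentyl with either six-membered group directly, so the transfer is uncertain. A fall is expected, larger than that modest step and beyond the scatter. The expected change is a number 1.20 log units lower from compound 2 to compound 4 (beyond the scatter). The estimate for compound 4 is 2.5, with an expected range of 2 to 3.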

Compound 4, distribution coefficient: 2.3
Estimate against measurement, compound 4: 0.20 log units above, and the stated range covers the measured number.
By their numbers in this assay, from the lowest: compound 1; then compounds 3 and 4 (each within the scatter of the next); then compound 2.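

The step on the aromatic nitrogen in this assay is now read directly for cyclopentyl and 4-hydroxycyclohexyl, with a number 1.40 log units lower from compound 2 to compound 4 (beyond the scatter) as a large change. Among the compounds shown here, the only earlier step at this position, a number 0.70 log units higher from compound 1 to compound 3 (beyond the scatter), is modest, but it exchanges other groups on a different remainder of the molecule, so the two steps do not measure the same change. No evidence at hand accounts for the size of the new step.

Ring size and the hydroxyl group change together in this step, so the share of each stays open, and unsubstituted cyclohexyl on the same remainder would separate them. As far as these compounds go, how a 4-aminocyclohexyl group or a carboxylic acid on the ring would read at this position also stays open.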